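The compounds below may be only part of what the source reports. "The series", "measured", "known", "first", "only" and "open" are said of these compounds alone.

Measured so far in a functional assay on HCT-15 cells (Homo sapiens) for cytotoxicity, read by sulforhodamine B assay, tested at 10 uM; on this read-out lower numbers stand for less inhibition and higher numbers for more inhibition at the one concentration tested (going by the name of the read-out):

compound 1, `CC(C)(C)c1ccc(Cn2cc(-c3cn([C@H]4C[C@H](O)[C@@H](CO)O4)c(=O)[nH]c3=O)nn2)cc1`: 96.9%
compound 2, `CC(=O)OC[C@H]1O[C@@H](n2cc(-c3cn(Cc4ccc(C(C)(C)C)cc4)nn3)c(=O)[nH]c2=O)C[C@@H]1OC(C)=O`: 94.2%
compound 3, `CC(=O)OC[C@H]1O[C@@H](n2cc(-c3cc(C)no3)c(=O)[nH]c2=O)C[C@@H]1OC(C)=O`: 102%

All three numbers sit at a similar level at the single concentration tested. Compound 3 is not separated from compound 1 or compound 2: the gap to compound 1 and the gap to compound 2 both fall within the usual scatter of the read-out, so nothing can be said of an order among the three. Among the measured compounds shown here, no pair of measured compounds differs in one place only, so no single-change step is available from the data.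

Compound 4, `CCCCCc1cc(-c2cn([C@H]3C[C@H](OC(C)=O)[C@@H](COC(C)=O)O3)c(=O)[nH]c2=O)on1`, differs from compound 3 in one place: butyl in place of hydrogen on a saturated chain carbon bound to an aromatic carbon. Given that compound 3 gives 102% in this assay and that compounds 1 and 2 with quite different substituents land in the same region, no step beyond the scatter is expected in either direction. The step is estimated as a number 5 percentage points lower from compound 3 to compound 4 (within the scatter). For compound 4 the expected value in this assay is 97%, with a range from 82% to 105%.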

Compound 4, a percentage reported as inhibition, at one concentration (the size of the read-out at that concentration, not a potency): 98.7%
Compound 4: the middle estimate sits 1.7 percentage points below what was measured; the range from low to high includes it.
By their numbers in this assay, from the lowest: compounds 2, 1, 4 and 3 (each within the scatter of the next).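

In this assay the series gives its first single-change step, a number 3.3 percentage points lower from compound 3 to compound 4 (within the scatter): butyl in place of hydrogen on a saturated chain carbon bound to an aromatic carbon, which also reads as methyl to pentyl. At this position, then, the added butyl does not separate compound 4 from compound 3 at the one concentration tested, and since that read-out is not a potency, any difference that would show only at lower concentrations stays unseen. No measurement at hand bears on this result.

On these data alone, whether an amine or a carboxylic acid in place of the butyl, or a longer chain such as decyl, would step beyond the scatter from compound 3 remains open. The compounds shown also leave open how compound 3 and compound 4 would compare across a range of concentrations.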